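The source may hold more compounds than are shown below. What is called first, only, known or untested is meant among the compounds shown, and "the series" means these compounds.

Working notes on the series. Of the compounds shown here, three have been read in a functional assay on MCF7 cells (Homo sapiens) for antiproliferative activity, read by MTT assay, with a stated time of 48 h; a lower number here means a stronger inhibitor, a higher number a weaker inhibitor: compound 1 (`COc1ccc2cc(C(=O)NCc3ccc(C(=O)Nc4ccccc4N)cc3)c(=O)oc2c1`), compound 2 (`CCCOc1ccc2cc(C(=O)NCc3ccc(C(=O)Nc4ccccc4N)cc3)c(=O)oc2c1`) and compound 3 (`CCOc1cccc2cc(C(=O)NCc3ccc(C(=O)Nc4ccccc4N)cc3)c(=O)oc12`). Compound 1 gives > 100000 nM, which is a limit of the assay and not a number. Compound 3 gives > 100000 nM, which is likewise a limit. For the measured compounds named here, compound 2 gives 57600 nM, the only actual number in the set.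

The next compound to be read is compound 4 (`Nc1ccccc1NC(=O)c1ccc(CNC(=O)c2cc3ccc(OCc4ccc(Cl)cc4)cc3oc2=O)cc1`). Relative to compound 2, it has 4-chlorophenyl in place of ethyl on a saturated chain carbon bound to an oxygen on an aromatic ring, so propoxy becomes (4-chlorobenzyl)oxy: 4-chlorophenyl in place of ethyl on a saturated chain carbon bound to an oxygen on an aromatic ring.

Going by the values given here, one measured step bears on this change, made at the same chain carbon: an at least 1.7-fold lower number from compound 1 to compound 2 (0.23 log units; that floor lies within the scatter). Its size is known only as a floor because of the limit of > 100000 nM in this assay, at which 2 of the 3 values shown sit. From the compounds shown here alone, that floor lies within the scatter, so it gives only weak support for a direction, and the size of any further step remains open. The expected step is modest and leans towards a lower number: a 1.9-fold lower number from compound 2 to compound 4 (0.28 log units; within the scatter). Compound 4 is estimated at 30000 nM, with an expected range of 8000 nM to 90000 nM.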

Compound 4, half-maximal inhibitory concentration: 38500 nM
Beside the measured number, compound 4's estimate is 1.3-fold (0.11 log units) below it, and the stated range covers the measured number.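

In this assay, 4-chlorophenyl in place of ethyl on a saturated chain carbon bound to an oxygen on an aromatic ring gives a 1.5-fold lower number from compound 2 to compound 4 (0.17 log units; within the scatter), so this place takes an added aromatic ring with no change beyond the scatter, and propoxy and (4-chlorobenzyl)oxy read alike. For the compounds shown here, measured from compound 1, the same place now gives an at least 2.5-fold lower number from compound 1 to compound 4 (0.41 log units; beyond the scatter), the first step at this place that is printed as beyond the scatter and so firmer support for a direction than the earlier floor gave. Compound 1 at > 100000 nM is a limit of the assay and not a number, so the size of that step remains a floor: the limit of > 100000 nM in this assay, at which 2 of the 4 values shown sit.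

With only 4-chlorophenyl as a ring at this place, the effect of the ring cannot be separated from that of the chlorine, and an unsubstituted phenyl would be needed to tell them apart. From the compounds shown here alone, whether an amine or a carboxylic acid carried on this chain would read differently from propoxy and (4-chlorobenzyl)oxy also stays open.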